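A few compounds are considered here, and "the series" means these few. Any claim that something is new, unique, unknown or untested is made for them only; others in the source may bear on it.

Measured so far in a functional assay on A2780 cells (Homo sapiens) for antiproliferative activity, read by CellTiter-Glo, with a stated time of 72 h; on this read-out lower numbers stand for stronger inhibition and higher numbers for weaker inhibition

Compound 1 (`C[C@H](NC(=O)c1cccc(F)c1)c1ccc(NC(=O)N2CC(c3cccnc3)C2)cc1`) gives 2.3 nM
Compound 2 (`C[C@H](NC(=O)C1CCOCC1)c1ccc(NC(=O)N2CC(c3cccnc3)C2)cc1`) gives 17 nM

Of these two compounds, compound 1 stands lowest, which makes it the stronger inhibitor on this read-out. Compound 3 (`C[C@H](NC(=O)c1cccc(F)c1)c1ccc(NC(=O)N2CC(c3ccc(N)nc3)C2)cc1`) keeps the 3-fluorophenyl of compound 1 and carries the change amino in place of hydrogen on an aromatic carbon in which pyridin-3-yl becomes 6-aminopyridin-3-yl.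

Within the data shown here, only one measured step is available, namely a 7.4-fold higher number from compound 1 to compound 2 (0.87 log units; beyond the scatter) when oxan-4-yl takes the place of 3-fluorophenyl on a carbonyl carbon. Among the measured compounds shown here, that step lies at a different place in the molecule, and no measured compound varies the pyridin-3-yl. For the measured compounds named here, it therefore shows only that a single change can move the number beyond the scatter, and it gives no direct guide to the amino group.

With so little to go on, a step within the scatter is expected in this assay, leaning slightly towards a higher number, though a larger rise remains possible. By this estimate, the expected move is a 1.7-fold higher number from compound 1 to compound 3 (0.24 log units; within the scatter) in all. Compound 3 is expected at 4 nM with an estimated range of 1 nM to 15 nM in this measurement.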

Compound 3, half-maximal inhibitory concentration: 7.6 nM
Estimate against measurement, compound 3: 1.9-fold (0.28 log units) below; measured number inside the range.
By their numbers in this assay, from the lowest: compound 1; then compound 3; then compound 2.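

In this assay, the pyridin-3-yl proves sensitive to substitution: amino in place of hydrogen, on the aromatic carbon next to the ring nitrogen and para to a large group, gives a 3.3-fold higher number from compound 1 to compound 3 (0.52 log units; beyond the scatter) on this change alone. Compound 3 still gives 7.6 nM, so the 6-aminopyridin-3-yl is accepted, but the number rises rather than falls, and this ring joins the group on the carbonyl carbon as a second place where one change moves the number beyond the scatter. No available evidence explains this shift.

The compounds shown leave open whether the rise belongs to the amino group itself or would follow any group on this carbon, which a methyl, a methoxy or a dimethylamino group there could begin to separate. On these data alone, it also remains open whether the amino group would give a step of similar size on compound 2, where oxan-4-yl replaces the 3-fluorophenyl, since the two changes are not seen together in any compound here.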